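The source may hold more compounds than are shown below. What is called first, only, known or untested is meant among the compounds shown, and "the series" means these compounds.

Compound 1 `Cc1ccc(-c2c(C#N)[n+]([O-])c3cc(Cl)ccc3[n+]2[O-])cc1` carries a methyl group and a single chloro group, and in a physicochemical assay for lipophilicity, measured as octanol-water partition (on this read-out lower numbers stand for lower lipophilicity and higher numbers for higher lipophilicity), compound 1 gives 2.6. Compound 2 `COc1ccc(-c2c(C#N)[n+]([O-])c3ccccc3[n+]2[O-])cc1` has a methoxy group and no chloro group, and in this assay compound 2 gives 1.58. Compound 3 `COc1ccc(-c2c(C#N)[n+]([O-])c3cc(Cl)ccc3[n+]2[O-])cc1` joins the methoxy group with the chloro group; in this assay compound 3 gives 2.09. Going from compound 2 to compound 3 the change is chloro in place of hydrogen on an aromatic carbon, and it brought a number 0.51 log units higher from compound 2 to compound 3 (beyond the scatter). Compound 4 `Cc1ccc(-c2c(C#N)[n+]([O-])c3cc(Cl)c(Cl)cc3[n+]2[O-])cc1` has not yet been measured. It differs from compound 1 by chloro in place of hydrogen on an aromatic carbon, the same kind of change as that from compound 2 to compound 3, though not the same: in compound 4 the entering chloro group is ortho to a chloro group, whereas in compound 3 no such neighbour is present. The difference between the core of compound 1 and that of compound 2 is not broken down here. Resting on the step of a number 0.51 log units higher from compound 2 to compound 3 (beyond the scatter), compound 4 is expected to show a step of a number 0.50 log units higher from compound 1 to compound 4 (beyond the scatter) in this assay, close in size to the earlier one. The estimate for compound 4 is therefore 3.1, with a likely range from 2.8 to 3.4.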

Compound 4, partition coefficient: 3.1
Compound 4: middle estimate and measured number agree at the digits printed, and the stated range covers the measured number.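

In this assay, chloro in place of hydrogen on an aromatic carbon gave a number 0.50 log units higher from compound 1 to compound 4 (beyond the scatter), while the same kind of change on the other core gave a number 0.51 log units higher from compound 2 to compound 3 (beyond the scatter), so the step kept nearly the same size when carried from one core to the other. Within the data shown here, this rests on only two pairs, however, and they are not exact copies of one change: the entering chloro group in compound 4 is ortho to a chloro group, whereas the one in compound 3 has no chloro group ortho to it, so the result does not show that the step would hold at other places or on other cores. Nothing available here explains why the two steps came out so alike.

The compounds shown leave open whether a second chloro group would add a similar step on a core carrying the methoxy group. They also leave open how an amine, a carboxylic acid or a longer chain would behave in this assay if it entered in place of the hydrogen that chloro replaced.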